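The source may report more compounds than this note shows. Statements on the series, on what has been measured and on what is new or still open speak of the compounds shown alone.

Three compounds share a core. In an assay on A7R5 cells for displacement of a labelled ligand from Endothelin-1 receptor (Rattus norvegicus) (on this read-out lower numbers stand for stronger inhibition and higher numbers for weaker inhibition), compound 1 `Cc1onc(NS(=O)(=O)c2ccc(N)cc2)c1I` gives 11000 nM. Compound 2 `CCc1onc(NS(=O)(=O)c2ccc(C(C)(C)C)cc2)c1Sc1cccc(OC)c1` gives 800 nM, and compound 3 `COc1cccc(Sc2c(NS(=O)(=O)c3ccc(C(C)(C)C)cc3)noc2CCCCC=O)c1` gives 1400 nM. Compound 3 thus holds the second highest of the three numbers, with compound 2 nearest to it and compound 1 furthest away.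

Compound 4 `COc1cccc(Sc2c(NS(=O)(=O)c3ccc(C(C)(C)C)cc3)noc2CCO)c1` differs from compound 3 by hydroxy in place of 2-formylethyl on a saturated chain carbon, two bonds along the chain from an aromatic carbon. For the measured compounds named here, only one measured step touches this same place on the chain: a 1.8-fold higher number from compound 2 to compound 3 (0.24 log units; within the scatter), a change that stayed within the scatter. Nothing here suggests that a hydroxy at this place behaves differently, so the estimated step is a 1.4-fold lower number from compound 3 to compound 4 (0.15 log units; within the scatter), with no shift beyond the scatter expected. Compound 4 is therefore estimated at 1000 nM, within a range from 400 nM to 2500 nM.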

Compound 4, half-maximal inhibitory concentration: 770 nM
Beside the measured number, compound 4's estimate is 1.3-fold (0.11 log units) above it; low and high end bracket the measured number.
By their numbers in this assay, from the lowest: compounds 4, 2 and 3 (each within the scatter of the next); then compound 1.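

In this assay, a second change at this place on the chain also stays small: hydroxy in place of 2-formylethyl gives a 1.8-fold lower number from compound 3 to compound 4 (0.26 log units; within the scatter), and hydroxy in place of hydrogen gives a 1.0-fold lower number from compound 2 to compound 4 (0.02 log units; within the scatter). Hydrogen, hydroxy and 2-formylethyl at this place thus all lie within the scatter of one another, so none of these swaps, including the one adding a hydrogen-bond donor, separates the compounds. No supporting data bear on why this is so.

On these data alone, whether an amine or a carboxylic acid at this place would move the number beyond the scatter remains open.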